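The source may hold more compounds than are shown below. What is called first, only, known or untested is meant among the compounds shown, and "the series" means these compounds.

Compound 2 `O=C1CC(c2ccccc2F)C(=O)N1CN1CCN(c2ccc(Cl)cc2)CC1` is the starting point of this step. Among the measured compounds shown here, in a functional assay on the whole organism (strain CF-1 albino) with Mus musculus as the target, with a stated time of 4 h (on this read-out higher numbers stand for an effect only at larger amounts of compound and lower numbers for an effect already at smaller amounts), compound 2 gives 100 mg/kg, the second highest of the three numbers measured so far. Compound 1 `O=C1CC(c2ccccc2F)C(=O)N1CN1CCN(c2ccc(F)cc2)CC1` gives 30 mg/kg, and putting chloro in place of fluoro on an aromatic carbon brings a 3.3-fold higher number from compound 1 to compound 2 (0.52 log units; beyond the scatter). Compound 3 `O=C1CC(c2ccccc2Br)C(=O)N1CN1CCN(c2ccc(Cl)cc2)CC1` gives 300 mg/kg, reached from compound 2 by bromo in place of fluoro on an aromatic carbon, a step of a 3.0-fold higher number from compound 2 to compound 3 (0.48 log units; beyond the scatter). Both measured steps raise the number modestly, and both merely swap one halogen for another on an aromatic carbon.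

Compound 4 `O=C1CC(c2ccccc2F)C(=O)N1CN1CCN(c2ncccn2)CC1` differs from compound 2 in a different way: pyrimidin-2-yl in place of 4-chlorophenyl on an amine nitrogen in a ring. Here a whole 4-chlorophenyl group leaves and a pyrimidin-2-yl group enters on the amine nitrogen in a ring, so neither measured step is a close match for this change. The step from compound 1 to compound 2 shows that altering this part of the molecule can move the number beyond the scatter, so a shift in either direction is possible; with no closer comparison available, the estimate stays near the value of compound 2 and carries a wide range. Compound 4 is expected to give 100 mg/kg, between 30 mg/kg and 300 mg/kg, which would amount to a step of no change at the digits printed from compound 2 to compound 4 (within the scatter).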

Compound 4, minimum effective dose: 100 mg/kg
Compound 4: the middle estimate sits on the measured number at the digits printed; the range from low to high includes it.
By their numbers in this assay, from the lowest: compound 1; then compounds 2 and 4 (each within the scatter of the next); then compound 3.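

In this assay, pyrimidin-2-yl in place of 4-chlorophenyl on the amine nitrogen in a ring gives no change at the digits printed from compound 2 to compound 4 (within the scatter), so this read-out does not separate a carbon-only aromatic ring bearing chlorine from an aromatic ring with hetero atoms and hydrogen-bond acceptors. Pyrimidin-2-yl in place of 4-fluorophenyl gives a 3.3-fold higher number from compound 1 to compound 4 (0.52 log units; beyond the scatter), so among the three groups shown at this position, 4-fluorophenyl alone stands apart, with an effect already at a smaller amount of compound, and the earlier halogen swap alone could not show that a very different ring would match the chlorinated one. The data shown offer no measurement that would explain this pattern.

All the groups shown on this nitrogen are aromatic rings, so it remains open how a plain phenyl ring, a pyridin-2-yl ring or a short alkyl chain such as ethyl would fare there. From the compounds shown here alone, it is also open whether pyrimidin-2-yl would match 4-chlorophenyl in the same way alongside the bromo group of compound 3.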